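Working notes on cytotoxicity ahead of compound 4

This account rests on a few compounds, and the source may have more. Where it says the series, first, only, none or still open, it means among the compounds named here.

Compound 1 `Cc1ncc([N+](=O)[O-])n1CC(O)CN1CCCC1` and compound 2 `Cc1ncc([N+](=O)[O-])n1CC(O)CN1CCC(C)CC1` share a core with compound 3 `CCCCN1CCN(C(=S)SCC(O)Cn2cc([N+](=O)[O-])nc2C)CC1`. In a toxicity assay on HeLa cells (Homo sapiens) for cytotoxicity, read by MTT assay, with a stated time of 24 h (a lower number here means a stronger inhibitor, a higher number a weaker inhibitor), compound 1 gives > 5000000 nM, which is a limit of the assay and not a number. In this assay compound 2 gives > 5000000 nM, again a limit rather than a number. Among the measured compounds shown here, compound 3 is the one member with a measured number: in this assay compound 3 gives 4330000 nM. The other two values sit at the limit of > 5000000 nM in this assay, at which 2 of the 3 values shown sit. For the measured compounds named here, no step between measured compounds exists, so nothing measured tells how a change on the amine nitrogen in the ring moves this read-out.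

Compound 4 `COc1ccccc1N1CCN(C(=S)SCC(O)Cn2cc([N+](=O)[O-])nc2C)CC1` is the next compound. It differs from compound 3 by 2-methoxyphenyl in place of butyl on an amine nitrogen in a ring. Going by the values given here, with no measured step to lean on, the expected step from compound 3 to compound 4 is a 1.4-fold lower number from compound 3 to compound 4 (0.16 log units; within the scatter), a shift not beyond the scatter in either direction. In this assay compound 4 is expected to give 3000000 nM, within the range from 1000000 nM to 6000000 nM.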

Compound 4, half-maximal inhibitory concentration: > 5000000 nM
Compound 4 was reported as a limit; the forecaster's own chance of this, stated with the estimate: 35%; at least 1.6-fold (0.22 log units) between middle value and limit.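

In this assay, among the compounds shown here, the first step at this position can now be read: 2-methoxyphenyl in place of butyl on an amine nitrogen in a ring gives an at least 1.1-fold higher number from compound 3 to compound 4 (0.06 log units; that floor lies within the scatter). Compound 4 gives > 5000000 nM, which is a limit and not a number, so this step has only a floor, and that floor does not establish a real difference from butyl. Adding an aromatic ring and a methoxy group at this position therefore brings no measurable gain in cytotoxicity, and the series gathers further at one limit: the limit of > 5000000 nM in this assay, at which 3 of the 4 values shown sit.

From the compounds shown here alone, it remains open whether an octyl chain or a carboxylic acid in place of butyl would move the read-out clearly away from that limit. For the compounds shown here, with compound 3 still the only member holding a number, the true size of this step also remains open.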